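Amide variation at the saturated ring of the shared core

A few compounds are considered here, and "the series" means these few. Any claim that something is new, unique, unknown or untested is made for them only; others in the source may bear on it.

Compound 1 `O=C1NCCc2nc(C#Cc3ccccc3)sc21`: 112 nM
Compound 2 `O=C1NCCc2nc(C#Cc3ccccc3F)sc21`: 1500 nM
Compound 3 `O=C(C1CC1)N1CCc2nc(C#Cc3ccccc3)sc2C1`: limit, > 10000 nM

The read-out is an assay on HEK293 cells for positive allosteric modulation of metabotropic glutamate receptor 5 (Homo sapiens), read by FLIPR, with a stated time of 1 h; on this read-out higher numbers stand for an effect only at larger amounts of compound and lower numbers for an effect already at smaller amounts. Compound 3 sits at the assay limit, > 10000 nM, with no number beyond it (the limit of > 10000 nM in this assay, at which 1 of the 3 values shown sits). Compound 4 `O=C(C1CCCO1)N1CCc2nc(C#Cc3ccccc3)sc2C1` differs from compound 3 in one place: oxolan-2-yl in place of cyclopropyl on a carbonyl carbon. Among the measured compounds shown here, the only measured step, a 13-fold higher number from compound 1 to compound 2 (1.13 log units; beyond the scatter), concerns a fluoro on the aromatic ring of compounds carrying the amide hydrogen, and so does not bear on an exchange at the carbonyl of compound 3. With compound 3 at the limit, the expectation for compound 4 is no step beyond the scatter, a step that the limit leaves unreadable from compound 3 to compound 4. Compound 4 is therefore expected at about 12000 nM, within 3000 nM to 40000 nM, most likely again reported only as a limit.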

Compound 4, half-maximal effective concentration: 790 nM
Beside the measured number, compound 4's estimate is 15-fold (1.18 log units) above it; the measured number lies below the stated range.
By their numbers in this assay, from the lowest: compound 1; then compounds 4 and 2 (each within the scatter of the next). At a limit, above all of these: compound 3.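

At the carbonyl carbon on the amide-type ring nitrogen, oxolan-2-yl in place of cyclopropyl gives, in this assay, an at least 12-fold lower number from compound 3 to compound 4 (1.10 log units; beyond the scatter). The group on this carbonyl therefore decides whether the series yields a readable number at all. Compound 3 is a limit and not a number, so the full size of the step stays unread: the limit of > 10000 nM in this assay, at which 1 of the 4 values shown sits.

Oxolan-2-yl brings both a ring oxygen and a larger ring, and the compounds shown do not separate the two. Cyclopentyl or tetrahydropyran-2-yl on the same carbonyl would bear on that question.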